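The source may hold more compounds than are shown below. What is called first, only, known or untested is meant among the compounds shown, and "the series" means these compounds.

Measured so far:
Compound 1, `C=C1CCCC(C)(C)C1CC[C@]1(C)CC[C@@H]([C@@H](C)C(=O)O)OO1`: in a functional assay on NCI-H460 cells (Homo sapiens) for inhibition (on this read-out higher numbers stand for weaker inhibition of growth and lower numbers for stronger inhibition of growth), compound 1 gives only a limit, > 10000 nM.
Compound 2, `C=C1CCCC(C)(C)C1CC[C@]1(C)CC[C@H]([C@@H](C)C(=O)OC)OO1`: in this assay compound 2 gives 910 nM.
Compound 3, `C=C1CCC[C@H]2[C@](C)(CC[C@]3(C)CC[C@@H]([C@@H](C)C(=O)O)OO3)[C@@H](C)CC[C@]12C`: in this assay compound 3 gives 600 nM.

Compound 3 holds the lowest of the two numbers that exist, but the number of compound 2 sits within the scatter of it, so the two cannot be ordered. Compound 1 stands apart as a limit (the limit of > 10000 nM in this assay, at which 1 of the 3 values shown sits). Compound 4, `C=C1CCC[C@H]2[C@](C)(CC[C@]3(C)CC[C@H]([C@@H](C)C(=O)O)OO3)[C@@H](C)CC[C@]12C`, is the partner of compound 3 in configuration: the two compounds have the same atoms and bonds and differ only in configuration as drawn: 1 of 7 stereo elements differ; a stereocentre at a saturated ring carbon is drawn S in compound 3 and R in compound 4. Among the measured compounds shown here, no pair of measured compounds differs in one place, so there is no measured step to lean on; compounds 1 and 2 differ both at this stereocentre and at the acid, and compound 1 is a limit, so their pair gives no isolated read of the configuration. The same inversion is therefore expected to cost something, a step of a 2.5-fold higher number from compound 3 to compound 4 (0.40 log units; beyond the scatter), with wide uncertainty in either direction. Compound 4 is estimated at 1500 nM, with a range from 400 nM to 8000 nM.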

Compound 4, concentration for 50% growth inhibition: 1590 nM
Compound 4: the middle estimate sits 1.1-fold (0.03 log units) below what was measured; the measured number falls inside the stated range.
By their numbers in this assay, from the lowest: compounds 3, 2 and 4 (each within the scatter of the next, the first and the last beyond it). At a limit, above all of these: compound 1.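

In this assay, among the compounds shown here, the inversion of this one saturated ring carbon from S to R gives a 2.7-fold higher number from compound 3 to compound 4 (0.42 log units; beyond the scatter) and is the first step that can be read at a single place. The change is modest, and measurable inhibition of growth remains on this core with either configuration. The step can be laid on the configuration and on nothing else, for this reason: the fact that compounds 3 and 4 differ only in the configuration as drawn.

Compound 1 gives only a limit of > 10000 nM and differs from compound 2 both at this stereocentre and at the acid, and the effect of the inversion on that core stays unread. Also open, on these data alone, is what a primary amide in place of the carboxylic acid would do on the core of compound 3 and compound 4.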